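Chloro for bromo on the anilide of compound 3

The source may hold more compounds than are shown below. What is called first, only, known or untested is meant among the compounds shown, and "the series" means these compounds.

Compound 1 `COc1cccc(NC(=O)COc2cc(C)nc3ccc(OC)cc23)c1` gives 24700 nM in an ADME assay on HepG2 cells (Homo sapiens) for cytotoxicity, read by trypan blue exclusion, with a stated time of 48 h, in the presence of a further agent that is not named here; a lower number here means that less compound is tolerated, a higher number that more compound is tolerated.
Compound 2 `COc1ccc(NC(=O)COc2cc(C)nc3ccc(OC)cc23)cc1` gives > 142000 nM, a limit of this assay.
Compound 3 `COc1ccc2nc(C)cc(OCC(=O)Nc3ccc(Br)cc3)c2c1` gives > 125000 nM, also a limit of this assay.

Compound 3 thus stands at a limit in this assay, and compound 2 stands at a limit too, so only compound 1 gives a number. Compound 4 `COc1ccc2nc(C)cc(OCC(=O)Nc3ccc(Cl)cc3)c2c1` differs from compound 3 by chloro in place of bromo on an aromatic carbon. Among the compounds with values here, no measured step is a halogen swap; the steps of an at least 5.7-fold higher number from compound 1 to compound 2 (0.75 log units; beyond the scatter) and an at least 5.0-fold higher number from compound 1 to compound 3 (0.70 log units; beyond the scatter) only show that 4-substituted anilides reach the limits the limit of > 125000 nM in this assay, at which 1 of the 3 values shown sits, and (the limit of > 142000 nM in this assay, at which 1 of the 3 values shown sits), and the step that the two limits leave unreadable from compound 2 to compound 3 is not readable. The expected step is therefore a number no higher from compound 3 to compound 4 (the limit leaves the size open), none beyond the scatter, and compound 4 is estimated at 125000 nM (range 50000 nM to 300000 nM), most likely again as a limit.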

Compound 4, half-maximal cytotoxic concentration: 71100 nM
Beside the measured number, compound 4's estimate is 1.8-fold (0.25 log units) above it; measured number inside the range.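

Compound 4 is the one 4-substituted anilide here that gives a number and not a limit. Swapping the substituent at this position reads as an at least 1.7-fold lower number from compound 3 to compound 4 (0.24 log units; that floor lies within the scatter), and as an at least 1.9-fold lower number from compound 2 to compound 4 (0.30 log units; that floor lies within the scatter), so neither step is shown to exceed the scatter. The higher number over the 3-methoxyphenyl anilide now has a measured size: a 2.9-fold higher number from compound 1 to compound 4 (0.46 log units; beyond the scatter).

As far as these compounds go, compound 2 and compound 3 stand at limits, so how far either lies from compound 4 stays open. Also open, from the compounds shown here alone, is how an amine or a carboxylic acid in place of chloro on this aromatic carbon would read in this assay.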